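Replacing One Group of Compound 2: Cell Tolerance

This account rests on a few compounds, and the source may have more. Where it says the series, first, only, none or still open, it means among the compounds named here.

The compounds measured so far in an ADME assay on MT4 cells (Homo sapiens) for inhibition, read by MTT assay, with a stated time of 5 days (a lower number here means that less compound is tolerated, a higher number that more compound is tolerated), are these:
Compound 1 `Cc1cc(C#N)cc(C)c1Oc1cc(Nc2ccc(C#N)cc2)ncc1[N+](=O)[O-]` gives 36100 nM
Compound 2 `Cc1cc(Br)cc(C)c1Oc1cc(Nc2ccc(C#N)cc2)ncc1[N+](=O)[O-]` gives 12300 nM
Compound 3 `COc1cccc(OC)c1Oc1cc(Nc2ccc(C#N)cc2)ncc1[N+](=O)[O-]` gives 319000 nM

Compound 2 has the lowest number of the three, with compound 1 nearest above it and compound 3 furthest above it. The next compound to be read is compound 4 `N#Cc1ccc(Nc2cc(Oc3c(Cl)cc(Cl)cc3Cl)c([N+](=O)[O-])cn2)cc1`, which carries 2,4,6-trichlorophenyl in place of 4-bromo-2,6-dimethylphenyl on an oxygen on an aromatic ring.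

Among the compounds with values here, only one measured step bears on this change. That step (a 2.9-fold lower number from compound 1 to compound 2 (0.47 log units; beyond the scatter)) is bromo in place of cyano on an aromatic carbon, and it is modest, though beyond the scatter. It replaces a single group, whereas compound 4 differs from compound 2 in the whole group on the oxygen. As far as these compounds go, compound 3 also has a different group there, and its value (319000 nM) is the highest of the three, so the upper side stays open. Within the data shown here, no measured compound carries the incoming group, so no step beyond the scatter is expected in this assay, though with wide uncertainty. The expected step (a 1.2-fold higher number from compound 2 to compound 4 (0.09 log units; within the scatter)) is small. Compound 4 is estimated at 15000 nM, within an expected range of 5000 nM to 50000 nM, in this assay.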

Compound 4, half-maximal cytotoxic concentration: 16200 nM
Estimate against measurement, compound 4: 1.1-fold (0.03 log units) below; low and high end bracket the measured number.
By their numbers in this assay, from the lowest: compounds 2 and 4 (each within the scatter of the next); then compound 1; then compound 3.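

In this assay, 2,4,6-trichlorophenyl in place of 4-bromo-2,6-dimethylphenyl on the oxygen gives a 1.3-fold higher number from compound 2 to compound 4 (0.12 log units; within the scatter). This replaces the whole group while the count of nine heavy atoms and the one six-membered aromatic ring of carbon only stay the same, and it shows that this position can take three chlorines in place of the bromine and both methyl groups with a step within the scatter, whereas the smaller exchange of one group, a 2.9-fold lower number from compound 1 to compound 2 (0.47 log units; beyond the scatter), lies beyond it. No measurement shown accounts for the two groups reading alike.

Compound 3, with yet another group on the same oxygen, gives 319000 nM, so the tolerance seen with the two halogen-bearing groups does not extend to every group at this position. Still open, as far as these compounds go, is how the number in this assay would respond to an amine or a carboxylic acid on the aromatic ring, or to a longer chain on the oxygen in place of that ring.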